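This account rests on a few compounds, and the source may have more. Where it says the series, first, only, none or still open, it means among the compounds named here.

Compound 1 `CN(C)CCn1cnnc1-c1cc(Oc2ccc(NC(=O)N/N=C/c3ccc(O)cc3)cc2F)ccn1` carries a 4-hydroxyphenyl ring on the carbon double-bonded to nitrogen at the end of the shared core. In a functional assay on HT-29 cells (Homo sapiens) for cytotoxicity, read by MTT assay, with a stated time of 72 h (on this read-out lower numbers stand for stronger inhibition and higher numbers for weaker inhibition), compound 1 gives 1920 nM. Compound 2 `CN(C)CCn1cnnc1-c1cc(Oc2ccc(NC(=O)N/N=C/c3ccc(O)c(F)c3)cc2F)ccn1` differs only by a fluorine on that ring, and in this assay compound 2 gives 3310 nM. The step of a 1.7-fold higher number from compound 1 to compound 2 (0.24 log units; within the scatter) is the only one measured. Of the two numbers compound 2 holds the nominally higher one, but its gap to compound 1 is within the scatter, so the two compounds cannot be told apart on this read-out.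

Compound 3 `Cc1cc(/C=N/NC(=O)Nc2ccc(Oc3ccnc(-c4nncn4CCN(C)C)c3)c(F)c2)cc(C)c1O` has not been measured. Its change from compound 2 is 4-hydroxy-3,5-dimethylphenyl in place of 3-fluoro-4-hydroxyphenyl on a carbon with a double bond to nitrogen. Going by the values given here, no measured step concerns a methyl-substituted ring at this place; the only step available, a 1.7-fold higher number from compound 1 to compound 2 (0.24 log units; within the scatter), alters the same ring and stays within the scatter. On that basis no step beyond the scatter is expected in this assay, in either direction. Compound 3 is therefore estimated at 2600 nM, with a range from 900 nM to 7500 nM. The expected step of a 1.3-fold lower number from compound 2 to compound 3 (0.10 log units; within the scatter) reflects this.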

Compound 3, half-maximal inhibitory concentration: 1220 nM
Beside the measured number, compound 3's estimate is 2.1-fold (0.33 log units) above it, within the range that was stated.
By their numbers in this assay, from the lowest: compounds 3, 1 and 2 (each within the scatter of the next, the first and the last beyond it).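

In this assay, a change to the ring on a carbon with a double bond to nitrogen now gives a step beyond the scatter: putting 4-hydroxy-3,5-dimethylphenyl in place of 3-fluoro-4-hydroxyphenyl gives a 2.7-fold lower number from compound 2 to compound 3 (0.43 log units; beyond the scatter), so the number at this position does respond to what the ring carries. The same entering group in place of plain 4-hydroxyphenyl gives a 1.6-fold lower number from compound 1 to compound 3 (0.20 log units; within the scatter), so those two cannot be told apart, and the clear separation holds only for the pair with the fluorinated ring. Nothing available here explains the step or shows which feature of the exchange is responsible for it.

The compounds shown leave open whether a single methyl on the 4-hydroxyphenyl ring would give a number different from that of two methyl groups, and whether chlorine or a methoxy group at this place would behave like methyl or like fluorine. They also leave open whether the hydroxyl itself matters, since every ring here keeps it and none carries an amine or a carboxylic acid in its stead.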